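The source may report more compounds than this note shows. Statements on the series, on what has been measured and on what is new or still open speak of the compounds shown alone.

Of the compounds shown here, three have been tested in a functional assay on KM12 cells (Homo sapiens) for cytotoxicity, read by sulforhodamine B assay, with a stated time of 48 h; on this read-out lower numbers stand for stronger inhibition of growth and higher numbers for weaker inhibition of growth. Compound 1 `ClCc1ccc(Cn2cnc3c(Cl)ncnc32)cc1` gives 10200 nM in this assay. Compound 2 `Nc1nc(Cl)c2ncn(Cc3ccc(CCl)cc3)c2n1` differs from compound 1 only by amino in place of hydrogen on an aromatic carbon; in this assay compound 2 gives 22900 nM, and the change produced a 2.2-fold higher number from compound 1 to compound 2 (0.35 log units; beyond the scatter). Compound 3 `ClCc1ccccc1Cn1cnc2c(Cl)ncnc21` is built from the same atoms as compound 1 joined differently; the difference between the two cores is not broken down here. In this assay compound 3 gives 33100 nM. For the measured compounds named here, compound 4 `Nc1nc(Cl)c2ncn(Cc3ccccc3CCl)c2n1` has not yet been measured; it differs from compound 3 by amino in place of hydrogen on an aromatic carbon, the same change as the one separating compound 1 and compound 2. Because the earlier step was a 2.2-fold higher number from compound 1 to compound 2 (0.35 log units; beyond the scatter), a step of similar size is expected for compound 4, namely a 2.0-fold higher number from compound 3 to compound 4 (0.29 log units; within the scatter). Compound 4 is therefore estimated to give 65000 nM in this assay, plausibly between 25000 nM and 170000 nM.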

Compound 4, concentration for total growth inhibition: 38900 nM
Compound 4: middle estimate off by 1.7-fold (0.22 log units), on the high side; low and high end bracket the measured number.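

In this assay, amino in place of hydrogen on an aromatic carbon gives a 1.2-fold higher number from compound 3 to compound 4 (0.07 log units; within the scatter). Set beside the earlier step, the two results cannot be told apart, so the effect of this change carries over between these two cores as far as the data can show: the same change on two cores in this assay, a 2.2-fold higher number (0.35 log units; beyond the scatter) from compound 1 to compound 2 and a 1.2-fold higher number (0.07 log units; within the scatter) from compound 3 to compound 4, 1.9-fold (0.28 log units) apart, within the scatter of two such steps. For the compounds shown here, with only two pairs and one read-out, this does not show that the change would act alike on other cores, and it does not show why the numbers move as they do.

The compounds shown leave open whether a methylamino or dimethylamino group on that same carbon would behave as amino does. They also leave open what a hydroxyl or methoxy group would do there.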